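Swapping a chlorobenzyl amine for a dimethylmorpholine: lipophilicity

The source may report more compounds than this note shows. Statements on the series, on what has been measured and on what is new or still open speak of the compounds shown alone.

Measured compounds:
- compound 1 `Cc1csc2cc([C@H](C)Nc3ncnc(N)c3C#N)c(-c3cccc(CN(C)CCCCN(C)Cc4ccccc4)c3)c(=O)n12`: 2.2
- compound 2 `Cc1csc2cc([C@H](C)Nc3ncnc(N)c3C#N)c(-c3cccc(CN(C)CCCN(C)Cc4ccc(Cl)cc4)c3)c(=O)n12`: 3.2
- compound 3 `Cc1csc2cc([C@H](C)Nc3ncnc(N)c3C#N)c(-c3cccc(CN4CCC(CN(C)Cc5ccccn5)CC4)c3)c(=O)n12`: 2

All three share one core and differ only in the amine-bearing side chain on the pendant phenyl ring. In a physicochemical assay for lipophilicity (on this read-out lower numbers stand for lower lipophilicity and higher numbers for higher lipophilicity), compound 2 gives 3.2, the highest of the three numbers; compound 1 lies a step below it, and compound 3 lies furthest below, both gaps beyond the scatter.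

Compound 4 `Cc1csc2cc([C@H](C)Nc3ncnc(N)c3C#N)c(-c3cccc(CN(C)CCCN4C[C@@H](C)O[C@@H](C)C4)c3)c(=O)n12` has not yet been measured in this assay. It differs from compound 2 in one place: 2,6-dimethylmorpholin-4-yl in place of (4-chlorobenzyl)(methyl)amino on a saturated chain carbon, three bonds along the chain from an amine nitrogen.

Among the measured compounds shown here, only one measured step bears directly on this change: a number 1.00 log units higher from compound 1 to compound 2 (beyond the scatter). That step added the chlorine-bearing benzyl group that compound 4 now loses, and compound 4 goes further by replacing the whole benzylamine with a ring that carries two hydrogen-bond acceptors instead of one. Compounds 1 and 3, which lack the chlorobenzyl group, both sit well below compound 2 in this assay. A drop beyond the scatter is therefore expected, and compound 4 is estimated to step a number 1.60 log units lower from compound 2 to compound 4 (beyond the scatter) from compound 2. In this assay compound 4 is expected to give about 1.6, with a likely range from 0.9 to 2.3.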

Compound 4, distribution coefficient: 1.5
Estimate against measurement, compound 4: 0.10 log units above, and the stated range covers the measured number.
By their numbers in this assay, from the lowest: compound 4; then compounds 3 and 1 (each within the scatter of the next); then compound 2.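

In this assay, placing 2,6-dimethylmorpholin-4-yl on this saturated chain carbon, three bonds along the chain from an amine nitrogen, gives a large step, a number 1.70 log units lower from compound 2 to compound 4 (beyond the scatter), so this position does not hold its reading when the (4-chlorobenzyl)(methyl)amino group is replaced. The fall is also more than a return to the level of the plain benzyl side chain, since the reading is a number 0.70 log units lower from compound 1 to compound 4 (beyond the scatter), even though that comparison involves a benzyl group without chlorine and a differently built chain. These numbers show the size and direction of the change, but nothing measured here accounts for it.

On these data alone, what stays open is which part of the new ring goes with the step: a plain morpholin-4-yl group, without the two methyl groups, or a piperidin-1-yl group, without the ring oxygen, would help separate those parts. Also open, as far as these compounds go, is whether 2,6-dimethylmorpholin-4-yl would give a step of similar size on a longer chain, or whether its other stereoisomers would read the same as the form in compound 4.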